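The compounds below may be only part of what the source reports. "The series", "measured", "known", "first", "only" and "open" are said of these compounds alone.

Measured compounds:
- Compound 1, `Cc1cc(COc2cccc(F)c2F)nc(-c2ccccn2)n1`: 398 nM
- Compound 2, `Cc1cc(COc2ccc(F)c(F)c2)nc(-c2ccccn2)n1`: 501 nM
- Compound 3, `Cc1cc(COc2cc(F)cc(F)c2F)nc(-c2ccccn2)n1`: 501 nM

All three were tested in a functional assay on cells for antagonist activity at Free fatty acid receptor 1 (Homo sapiens), read by TR-FRET and inositol phosphate accumulation, with a stated time of 2 h; a lower number here means a stronger inhibitor, a higher number a weaker inhibitor. Compound 1 and compound 2 are built from the same atoms joined differently; the difference between their two cores is not broken down here. Compound 3 arises from compound 1 by fluoro in place of hydrogen on an aromatic carbon, and this gave a 1.3-fold higher number from compound 1 to compound 3 (0.10 log units; within the scatter). Compound 2 and compound 3 show no difference at the digits read.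

Compound 4, `Cc1cc(COc2cc(F)c(F)cc2F)nc(-c2ccccn2)n1`, has not yet been measured in this assay. It arises from compound 2 by fluoro in place of hydrogen on an aromatic carbon. Among the measured compounds shown here, this is the same kind of change as the one from compound 1 to compound 3, but the surroundings differ: in compound 3 the new fluoro sits meta to a large group, while in compound 4 it sits ortho to a large group. Because the first such step gave a 1.3-fold higher number from compound 1 to compound 3 (0.10 log units; within the scatter), the expected step from compound 2 to compound 4 is a 1.2-fold higher number from compound 2 to compound 4 (0.08 log units; within the scatter), a small change within the scatter. Compound 4 is therefore expected to give about 600 nM in this assay, estimated to lie between 250 nM and 1500 nM.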

Compound 4, half-maximal inhibitory concentration: 398 nM
Beside the measured number, compound 4's estimate is 1.5-fold (0.18 log units) above it, and the stated range covers the measured number.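

Replacing a hydrogen on an aromatic carbon of compound 2 with a fluoro gave a 1.3-fold lower number from compound 2 to compound 4 (0.10 log units; within the scatter) in this assay. Set beside the same change on the core of compound 1, the two steps point in opposite directions, but the gap between them is no larger than repeated measurements could produce: the same change on two cores in this assay, a 1.3-fold higher number (0.10 log units; within the scatter) from compound 1 to compound 3 and a 1.3-fold lower number (0.10 log units; within the scatter) from compound 2 to compound 4, 1.6-fold (0.20 log units) apart, within the scatter of two such steps This shows that, on these two cores, the added fluoro produced no step beyond the scatter, but two small steps cannot establish a rule for other cores or tell whether the opposite directions are real.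

As far as these compounds go, all four compounds carry only fluoro groups on the six-membered aromatic ring of carbon only, so it remains open whether a methoxy, a nitrile or an amine there would move the number beyond the scatter. From the compounds shown here alone, it also remains open how a longer chain or a carboxylic acid in place of the methyl on the shared core would behave.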